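A few compounds are considered here, and "the series" means these few. Any claim that something is new, unique, unknown or untested is made for them only; others in the source may bear on it.

Measured so far in a functional assay on MCF7 cells (Homo sapiens) for antiproliferative activity, read by WST assay, with a stated time of 3 days; a higher number here means a weaker inhibitor, a lower number a stronger inhibitor:
- Compound 1 `O=c1[nH]c(=O)n([C@@H]2O[C@H](CO)[C@@H](O)[C@H]2O)c(I)c1F`: > 50000 nM, a limit of the assay and not a number
- Compound 2 `[N-]=[N+]=Nc1c(F)c(=O)[nH]c(=O)n1[C@@H]1O[C@H](CO)[C@@H](O)[C@H]1O`: 1000 nM
- Compound 3 `Nc1c(F)c(=O)[nH]c(=O)n1[C@@H]1O[C@H](CO)[C@@H](O)[C@H]1O`: 1400 nM

Compound 3 stands level with compound 2, since a 1.4-fold higher number from compound 2 to compound 3 (0.15 log units; within the scatter) lies within the scatter. Both are far from compound 1, which reaches only a limit.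

Compound 4 `CCc1c(F)c(=O)[nH]c(=O)n1[C@@H]1O[C@H](CO)[C@@H](O)[C@H]1O` keeps the shared core and changes one group: ethyl in place of amino on an aromatic carbon. All three measured steps changed the group at this same carbon. Two were large: an at least 50-fold lower number from compound 1 to compound 2 (1.69 log units; beyond the scatter) and an at least 35-fold lower number from compound 1 to compound 3 (1.55 log units; beyond the scatter). The third, a 1.4-fold higher number from compound 2 to compound 3 (0.15 log units; within the scatter), shows no change beyond the scatter. Among the compounds with values here, this carbon can therefore matter a great deal, but no measured compound carries a carbon chain here, so the guide is loose. Compound 1 shows with its an at least 35-fold lower number from compound 1 to compound 3 (1.55 log units; beyond the scatter) that a swap of this group can cost much of the activity, so a higher number is expected in this assay, though a smaller step than that one. The expected change is a 2.9-fold higher number from compound 3 to compound 4 (0.46 log units; beyond the scatter). For compound 4 the estimated value is 4000 nM, with an expected range of 800 nM to 30000 nM.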

Compound 4, half-maximal inhibitory concentration: 31400 nM
Compound 4: the middle estimate sits 7.9-fold (0.89 log units) below what was measured; the whole stated range lies below it.
By their numbers in this assay, from the lowest: compounds 2 and 3 (each within the scatter of the next); then compound 4. At a limit, above all of these: compound 1.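

Among the compounds shown, compound 4 is the first with a carbon chain on this aromatic carbon, and it shows that losing the iodo group does not by itself bring activity. In this assay, ethyl in place of amino gives a 22-fold higher number from compound 3 to compound 4 (1.35 log units; beyond the scatter), and ethyl in place of azido gives a 31-fold higher number from compound 2 to compound 4 (1.50 log units; beyond the scatter), so the gain seen with those two nitrogen groups does not carry over to ethyl. Ethyl in place of iodo gives an at least 1.5-fold lower number from compound 1 to compound 4 (0.20 log units; that floor lies within the scatter), and this step is known only as a floor. The value of compound 1 is a limit and not a number: the limit of > 50000 nM in this assay, at which 1 of the 4 values shown sits.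

Going by these compounds, it remains open whether the smaller methyl or a longer propyl chain would behave like ethyl. A methylamino group or a hydroxyl group at this carbon could also show whether activity depends on a nitrogen or on something else.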